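The source may hold more compounds than are shown below. What is called first, only, known or untested is meant among the compounds shown, and "the series" means these compounds.

Compound 1, `O=C(O)CC/C=C\CC1COC(c2ccccc2Cl)OC1c1cccnc1`, gives 48 nM in an assay for inhibition of Thromboxane-A synthase (Homo sapiens), using microsomes; a lower number here means a stronger inhibitor, a higher number a weaker inhibitor.
Compound 2, `O=C(O)CC/C=C\CC1COC(c2cccs2)OC1c1cccnc1`, gives 71 nM in this assay.
Compound 3, `CC(C)(Oc1ccccc1)C1OCC(C/C=C\CCC(=O)O)C(c2cccnc2)O1`, gives 52 nM in this assay.

All three compounds share a core and differ only in the group attached to one saturated ring carbon. Compound 3 has the second highest of the three numbers, with compound 1 nearest and compound 2 furthest; the step of a 1.1-fold higher number from compound 1 to compound 3 (0.03 log units; within the scatter) and the step of a 1.4-fold lower number from compound 2 to compound 3 (0.14 log units; within the scatter) both fall within the scatter, as does the step of a 1.5-fold higher number from compound 1 to compound 2 (0.17 log units; within the scatter). So far, changing the group on that carbon has not moved the number beyond the scatter.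

Compound 4, `COc1ccc(OC(C)(C)C2OCC(C/C=C\CCC(=O)O)C(c3cccnc3)O2)cc1`, is not yet measured. It differs from compound 3 by methoxy in place of hydrogen on an aromatic carbon, a small addition on the outer ring of that same group. Going by the values given here, since every change at this position so far has stayed within the scatter, no step beyond the scatter is expected for compound 4, in either direction; the expected step is a 1.1-fold higher number from compound 3 to compound 4 (0.02 log units; within the scatter). The estimate for compound 4 in this assay is therefore 55 nM, ranging from 27 nM to 110 nM.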

Compound 4, half-maximal inhibitory concentration: 41 nM
Compound 4: the middle estimate sits 1.3-fold (0.13 log units) above what was measured; the measured number falls inside the stated range.
By their numbers in this assay, from the lowest: compounds 4, 1, 3 and 2 (each within the scatter of the next).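

Turning phenoxy into 4-methoxyphenoxy gives a 1.3-fold lower number from compound 3 to compound 4 (0.10 log units; within the scatter) in this assay. The earlier steps shown here exchanged the whole group on the saturated ring carbon, whereas this one adds methoxy on an aromatic carbon within that group, para to a large group, and the number still stays within the scatter. So the picture of a position where changes have not moved the number beyond the scatter now also holds for a small addition on the outer ring of the group, though nothing measured here offers a reason for this result.

The compounds shown leave open whether any group on this ring can move the number beyond the scatter, as an amine or a carboxylic acid in place of methoxy might. Also open, on these data alone, is whether methoxy on another aromatic carbon of the ring would behave the same way.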